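The compounds below may be only part of what the source reports. "The series", "measured", "known", "first", "only" and "open" are said of these compounds alone.

Measured so far in an assay on U2OS cells for inhibition of secreted frizzled-related protein 1 (Homo sapiens), read by a luciferase reporter, with a stated time of 18 h; on this read-out lower numbers stand for an effect already at smaller amounts and higher numbers for an effect only at larger amounts of compound:
compound 1 `O=C(c1ccc(Cl)nc1)N1CCC(NS(=O)(=O)c2cc(S(=O)(=O)c3ccccc3)ccc2C(F)(F)F)CC1` — 140 nM
compound 2 `CC(C)(C)OC(=O)N1CCC[C@H]1C(=O)N1CCC(NS(=O)(=O)c2cc(S(=O)(=O)c3ccccc3)ccc2C(F)(F)F)CC1` — 60 nM

Among the compounds with values here, compound 2 holds the lowest of the two numbers; the single step recorded, a 2.3-fold lower number from compound 1 to compound 2 (0.37 log units; beyond the scatter), is a modest gain. Compound 3 `O=C([C@@H]1CCNC1)N1CCC(NS(=O)(=O)c2cc(S(=O)(=O)c3ccccc3)ccc2C(F)(F)F)CC1` differs from compound 2 by pyrrolidin-3-yl in place of 1-(tert-butoxycarbonyl)pyrrolidin-2-yl on a carbonyl carbon. Within the data shown here, no measured step mirrors this exchange: the one step available replaces 6-chloropyridin-3-yl with 1-(tert-butoxycarbonyl)pyrrolidin-2-yl, not the other way round, so it gives only indirect guidance. A moderate rise in number is expected, a 2.5-fold higher number from compound 2 to compound 3 (0.40 log units; beyond the scatter). Compound 3 is estimated at 150 nM in this assay, within 45 nM to 500 nM.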

Compound 3, half-maximal effective concentration: 380 nM
For compound 3 the middle estimate is 2.5-fold (0.40 log units) below the measured one, within the range that was stated.
By their numbers in this assay, from the lowest: compound 2; then compound 1; then compound 3.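

In this assay a free pyrrolidin-3-yl on this carbonyl carbon gives the highest number of the three compounds: a 6.3-fold higher number from compound 2 to compound 3 (0.80 log units; beyond the scatter), and a 2.7-fold higher number from compound 1 to compound 3 (0.43 log units; beyond the scatter). The step from compound 2 removes the tert-butoxycarbonyl group and moves the ring attachment from the 2-yl to the 3-yl together, so neither change can be assigned the rise alone. No available evidence bears on the reason for these rises. Open, on these data alone, is whether an unsubstituted pyrrolidin-2-yl, or a pyrrolidin-3-yl with an acetyl group on its ring nitrogen, would bring the number back down. As far as these compounds go, the effect of the opposite stereocentre also remains open.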